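A few compounds are considered here, and "the series" means these few. Any claim that something is new, unique, unknown or untested is made for them only; others in the source may bear on it.

In a functional assay on A-375 cells (Homo sapiens) for inhibition, read by CCK-8 assay, with a stated time of 72 h (on this read-out higher numbers stand for weaker inhibition and lower numbers for stronger inhibition), compound 1 (`Nc1ccccc1NC(=O)c1ccc(CNC(=O)c2n[nH]cc2NC(=O)c2ccccc2Cl)cc1`) gives 2110 nM, compound 3 (`Nc1ccccc1NC(=O)c1ccc(CNC(=O)c2n[nH]cc2NC(=O)c2ccccc2F)cc1`) gives 2270 nM and compound 2 (`O=C(NO)c1ccc(CNC(=O)c2n[nH]cc2NC(=O)c2c(Cl)cccc2Cl)cc1`) gives 5050 nM. Compound 3 thus sits level with compound 1 within the scatter, and both lie lower than compound 2. Compound 4 (`O=C(NO)c1ccc(CNC(=O)c2n[nH]cc2NC(=O)c2ccccc2F)cc1`) differs from compound 3 as follows: hydroxy in place of 2-aminophenyl on an amide-type nitrogen. Within the data shown here, the only measured step, a 1.1-fold higher number from compound 1 to compound 3 (0.03 log units; within the scatter), exchanges chloro for fluoro and does not touch this place, so no measured step sizes the change directly. Compound 2 also has hydroxy on the amide-type nitrogen, though with different halogens, and its 5050 nM points to a moderately higher number. Compound 4 is therefore expected near 4000 nM, with an estimated range of 1800 nM to 9000 nM. The expected size is a 1.8-fold higher number from compound 3 to compound 4 (0.25 log units; within the scatter).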

Compound 4, half-maximal inhibitory concentration: 3010 nM
For compound 4 the middle estimate is 1.3-fold (0.12 log units) above the measured one; the range from low to high includes it.
By their numbers in this assay, from the lowest: compounds 1, 3, 4 and 2 (each within the scatter of the next, the first and the last beyond it).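

In this assay the exchange of 2-aminophenyl for hydroxy on the amide-type nitrogen now has a measured size, a 1.3-fold higher number from compound 3 to compound 4 (0.12 log units; within the scatter), so with 2-fluorophenyl in place the two groups cannot be told apart. The halogen pattern can now also be read with hydroxy on that nitrogen: a 1.7-fold lower number from compound 2 to compound 4 (0.22 log units; within the scatter) does not separate 2-fluorophenyl from 2,6-dichlorophenyl on the carbonyl carbon. No supporting evidence bears on why these groups read alike.

Open, on these data alone, is how a methoxy group or a longer alkyl chain on the amide-type nitrogen would read, and whether 2-aminophenyl and hydroxy also stay level with 2,6-dichlorophenyl on the carbonyl carbon.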